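A Methyl Added to the Core of Compound 1

The source may report more compounds than this note shows. Statements on the series, on what has been measured and on what is new or still open speak of the compounds shown alone.

Compound 1 `CCCc1nc(C)c2ccnc(Nc3cc[nH]n3)n12` stands at the lowest of the two numbers recorded in a functional assay for inhibition, with Homo sapiens as the target (on this read-out lower numbers stand for stronger inhibition and higher numbers for weaker inhibition), where compound 1 gives 25000 nM. Its nearest neighbour, compound 3 `Cc1ncn2c(Nc3cc[nH]n3)nccc12`, gives 57000 nM in this assay. Compound 2 `Cc1ncn2c(NCc3ccco3)nncc12` reaches only a limit of > 48000 nM in this assay. For the measured compounds named here, the single step between measured compounds is a 2.3-fold higher number from compound 1 to compound 3 (0.36 log units; beyond the scatter), which removes a propyl from the core. Compound 4 `CCCc1nc(C)c2c(C)cnc(Nc3cc[nH]n3)n12` differs from compound 1 by methyl in place of hydrogen on an aromatic carbon. Going by the values given here, no measured step concerns a methyl entering at this place, so the propyl step of compound 1 to compound 3 bears on it only loosely. In this assay the expected step is therefore a 1.3-fold lower number from compound 1 to compound 4 (0.10 log units; within the scatter), within the scatter. Compound 4 is estimated at 20000 nM in this assay, in a range from 8000 nM to 50000 nM.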

Compound 4, half-maximal inhibitory concentration: > 48000 nM
Compound 4 was reported as a limit (the forecaster's own chance of this, stated with the estimate: 15%); at least 2.4-fold (0.38 log units) between middle value and limit.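

In this assay compound 4 gives > 48000 nM, which is a limit and not a number. The step is an at least 1.9-fold higher number from compound 1 to compound 4 (0.28 log units; that floor lies within the scatter), so a methyl on this aromatic carbon, para to the (1H-pyrazol-3-yl)amino group, shows no stronger inhibition, though the data cannot establish a real loss. That limit recurs among the compounds shown: the limit of > 48000 nM in this assay, at which 2 of the 4 values shown sit.

On these data alone, the true size of this step stays open. So does what an amine, a fluorine atom or a longer chain would do on this same aromatic carbon.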